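This account rests on a few compounds, and the source may have more. Where it says the series, first, only, none or still open, it means among the compounds named here.

Three compounds have been measured in an assay on membranes from brain for displacement of a labelled ligand from Sigma non-opioid intracellular receptor 1 (Cavia porcellus), read by scintillation counting, with a stated time of 120 min; a lower number here means a stronger inhibitor, a higher number a weaker inhibitor:

Compound 1, `CN(C)CC[C@H]1CCC[C@@H](c2ccccc2)C1`, gives 10 nM.
Compound 2, `CN(C)CCC1CCCC(c2ccccc2)C1`, gives 4.2 nM.
Compound 3, `c1ccc([C@H]2CCC[C@@H](CCN3CCCC3)C2)cc1`, gives 3.6 nM.

Among these three, compound 1 stands with the highest number. Its nearest neighbour is compound 2, reached by the step of a 2.4-fold lower number from compound 1 to compound 2 (0.38 log units; beyond the scatter), a pair that differs only in the fact that one of compounds 1 and 2 is drawn with a defined configuration and the other without, at the place where they differ. Among the measured compounds shown here, compound 3 shows a lower number than compound 1, and that gap also lies beyond the usual scatter; no single-point step links the two.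

The unmeasured compound 4, `NCC[C@H]1CCC[C@@H](c2ccccc2)C1`, is derived from compound 1 by amino in place of dimethylamino on a saturated chain carbon, two bonds along the chain from a saturated ring carbon. For the measured compounds named here, none of the measured steps touches this part of the molecule: the only step on record concerns the drawn configuration, not the amine, and compound 3 carries a different amine altogether without a counted difference to compound 1. The expectation therefore rests on compound 1 alone, and the direction of the change is open. Compound 4 is estimated at 40 nM, within a wide range from 10 nM to 160 nM, which corresponds to an expected step of a 4.0-fold higher number from compound 1 to compound 4 (0.60 log units; beyond the scatter).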

Compound 4, inhibition constant: 138 nM
Compound 4: middle estimate off by 3.5-fold (0.54 log units), on the low side, and the stated range covers the measured number.
By their numbers in this assay, from the lowest: compounds 3 and 2 (each within the scatter of the next); then compound 1; then compound 4.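

In this assay, the amine end of the chain proves to be a sensitive place: with amino in place of dimethylamino, the record shows a 14-fold higher number from compound 1 to compound 4 (1.14 log units; beyond the scatter). Among the compounds shown here, the only earlier step, a change in drawn configuration, was much smaller at a 2.4-fold lower number from compound 1 to compound 2 (0.38 log units; beyond the scatter), so this is the first sign that the 2-(dimethylamino)ethyl group matters more to the number than that difference does. Nothing recorded here accounts for the size of this step.

The compounds shown leave open whether the number depends on how many methyl groups the nitrogen carries, since methylamino, which lies between dimethylamino and amino, does not appear among them. They also leave open whether a longer chain carrying the same amino group would give a number closer to that of compound 1.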